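The compounds below may be only part of what the source reports. "The series", "measured", "known", "first", "only" and "open" are said of these compounds alone.

Measured so far:
- compound 1 `Cc1ccc(S(=O)(=O)N2C=CNC(=O)[C@H]2CC(=O)NC2CCOCC2(C)C)cc1`: 25.2 nM
- compound 2 `Cc1ccc(S(=O)(=O)N2C=CNC(=O)[C@H]2CC(=O)N[C@H]2CCN(C)CC2(C)C)cc1`: 0.42 nM

Both numbers come from an in vitro functional assay on cells for antagonist activity at B1 bradykinin receptor (Homo sapiens), read by luminescence and calcium flux, with a stated time of 2 h; a higher number here means a weaker inhibitor, a lower number a stronger inhibitor. Among the measured compounds shown here, compound 2 stands at the lower end of the two: the step of a 60-fold lower number from compound 1 to compound 2 (1.78 log units; beyond the scatter) separates it from compound 1, the only other compound measured, and that step lies well beyond the scatter.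

Compound 3 `Cc1ccc(S(=O)(=O)N2C=CNC(=O)[C@H]2CC(=O)N[C@H]2CCN(C3CCC3)CC2(C)C)cc1` has not yet been measured in this assay. It differs from compound 2 by cyclobutyl in place of methyl on an amine nitrogen in a ring. For the measured compounds named here, no measured step changes this part of the molecule: the one step recorded, from compound 1 to compound 2, swaps a whole ring, not the group on the ring nitrogen, so it gives no direct guide. With nothing pointing one way, the expectation is for compound 3 to stay close to compound 2, with a step of a 1.4-fold higher number from compound 2 to compound 3 (0.15 log units; within the scatter) that may not exceed the scatter. The estimate for compound 3 in this assay is 0.6 nM, within 0.15 nM to 2.5 nM.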

Compound 3, half-maximal inhibitory concentration: 0.74 nM
Compound 3: the middle estimate sits 1.2-fold (0.09 log units) below what was measured; the range from low to high includes it.
By their numbers in this assay, from the lowest: compounds 2 and 3 (each within the scatter of the next); then compound 1.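

On the amine nitrogen in the ring, cyclobutyl in place of methyl gives a 1.8-fold higher number from compound 2 to compound 3 (0.25 log units; within the scatter) in this assay, so the two compounds cannot be told apart in this measurement. The earlier step swapped a whole ring, whereas this one shows that the group on this nitrogen can grow from methyl to cyclobutyl, and gain a four-membered ring of carbon only, without a change that stands out from the scatter. Nothing at hand explains why the larger group is accepted here.

The compounds shown leave open how far this acceptance extends, for instance to a larger ring such as cyclohexyl, a longer chain such as hydroxyethyl, or an acetyl group on this nitrogen. They also leave open what a plain hydrogen at this position would give.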